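This account rests on a few compounds, and the source may have more. Where it says the series, first, only, none or still open, it means among the compounds named here.

Working notes on the series. Compound 1 `COc1cc(-c2nccn2C)cc(OC)c1OC` gives only a limit in a functional assay on HCT-15 cells (Homo sapiens) for antiproliferative activity, read by MTT assay, with a stated time of 72 h (a lower number here means a stronger inhibitor, a higher number a weaker inhibitor), the value for compound 1 being > 100000 nM. Compound 2 `CCn1ccnc1-c1cc(OC)c(OC)c(OC)c1` likewise gives only a limit in this assay, at > 100000 nM. The step between them, a step that the two limits leave unreadable from compound 1 to compound 2, is therefore unreadable, and both sit at the limit of > 100000 nM in this assay, at which 2 of the 3 values shown sit. Among the measured compounds shown here, compound 3 `COc1cc(-c2nccn2-c2ccc3sccc3c2)cc(OC)c1OC` is the one member that returns a number, giving 3300 nM in this assay.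

Compound 4 `COc1cc(-c2nccn2-c2cccc(C)c2)cc(OC)c1OC` is not yet measured. Relative to compound 1 the change is 3-methylphenyl in place of methyl on an aromatic nitrogen. For the measured compounds named here, no measured step covers this change directly: the only step, from compound 1 to compound 2, is unreadable between two limits, and the pair compound 1 and compound 3 shows a limit against a number without a computed step. Going by the values given here, what the numbers do show is that compound 3, bearing an aromatic group on the same ring nitrogen, is the only compound with a readable value, 3300 nM. Compound 1 and compound 2, which bear methyl and ethyl on that nitrogen, return no readable number. On that basis compound 4 is expected to come off the limit and give a number, with the step of an at least 11-fold lower number from compound 1 to compound 4 (1.04 log units; beyond the scatter) expected to be large in the direction of stronger inhibition. The estimate for compound 4 is 9000 nM, within 1500 nM to 60000 nM.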

Compound 4, half-maximal inhibitory concentration: 1600 nM
For compound 4 the middle estimate is 5.6-fold (0.75 log units) above the measured one, and the stated range covers the measured number.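

The 3-methylphenyl group on the aromatic nitrogen gives the series its second readable number in this assay, with an at least 62-fold lower number from compound 1 to compound 4 (1.79 log units; beyond the scatter) and an at least 62-fold lower number from compound 2 to compound 4 (1.79 log units; beyond the scatter). Readable activity with an aromatic group on this nitrogen therefore no longer rests on the group of compound 3 alone: compound 3 gives 3300 nM and compound 4 gives 1600 nM. Both steps are open-ended, with the far end of each set by a limit of the assay for compound 1 and for compound 2: the limit of > 100000 nM in this assay, at which 2 of the 4 values shown sit.

The step between the two limits cannot be read, so the compounds shown do not tell how a longer chain such as propyl or butyl on this nitrogen would read in this assay, or whether any size of saturated chain leaves the limit. Also open, going by these compounds, are what the methyl of the 3-methylphenyl group adds over a plain phenyl on the same nitrogen, and how an amine or a carboxylic acid on that six-membered ring would read.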